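Halogenated phenyl amides on a shared core

The compounds below may be only part of what the source reports. "The series", "measured", "known", "first", "only" and "open" are said of these compounds alone.

Compound 1 `CCN1CCN(c2cc(C)c3cc(NC(=O)c4ccccc4)ccc3n2)CC1` gives 14200 nM in a functional assay on MCF7 cells (Homo sapiens) for antiproliferative activity, read by MTT assay, with a stated time of 72 h; a lower number here means a stronger inhibitor, a higher number a weaker inhibitor. Compound 2 `CCN1CCN(c2cc(C)c3cc(NC(=O)c4cc(Cl)cc(Cl)c4)ccc3n2)CC1` gives 6090 nM, and compound 3 `CCN1CCN(c2cc(C)c3cc(NC(=O)c4ccc(F)c(F)c4)ccc3n2)CC1` gives 5230 nM, the lowest of the three numbers, though only compound 1 lies beyond the scatter from it. The two halogenated rings each brought a modest step: a 2.3-fold lower number from compound 1 to compound 2 (0.37 log units; beyond the scatter) and a 2.7-fold lower number from compound 1 to compound 3 (0.43 log units; beyond the scatter), while a 1.2-fold lower number from compound 2 to compound 3 (0.07 log units; within the scatter).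

Compound 4 `CCN1CCN(c2cc(C)c3cc(NC(=O)c4ccccc4Cl)ccc3n2)CC1` carries 2-chlorophenyl in place of 3,4-difluorophenyl on a carbonyl carbon. Among the measured compounds shown here, the only step between two halogenated phenyl rings, a 1.2-fold lower number from compound 2 to compound 3 (0.07 log units; within the scatter), was within the scatter, so for compound 4 the expectation in this assay is a step of a 1.3-fold higher number from compound 3 to compound 4 (0.13 log units; within the scatter), essentially none beyond the scatter. Compound 4 is accordingly estimated at 7000 nM, with a range of 3000 nM to 16000 nM.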

Compound 4, half-maximal inhibitory concentration: > 50000 nM
Compound 4 was reported as a limit; the forecaster's own chance of this, stated with the estimate: 5%; middle value at least 7.1-fold (0.85 log units) away from the limit.
By their numbers in this assay, from the lowest: compounds 3 and 2 (each within the scatter of the next); then compound 1. At a limit, above all of these: compound 4.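

In this assay, a halogen on the phenyl ring does not in itself lower the number: 2-chlorophenyl gives an at least 3.5-fold higher number from compound 1 to compound 4 (0.54 log units; beyond the scatter), opposite in direction to the steps to the 3,5-dichlorophenyl and 3,4-difluorophenyl rings. Substitution on this ring can therefore move the number much further than the earlier steps showed, with an at least 9.5-fold higher number from compound 3 to compound 4 (0.98 log units; beyond the scatter) and an at least 8.2-fold higher number from compound 2 to compound 4 (0.91 log units; beyond the scatter). The value for compound 4 is a limit, so these steps have no upper bound: the limit of > 50000 nM in this assay, at which 1 of the 4 values shown sits.

On these data alone, whether a methyl or an amine in place of the chloro of compound 4 would also reach this limit remains open. As far as these compounds go, the true size of the steps to compound 4 also remains open.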